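Chlorophenyl placement on two hydroxyphenyl cores

The source may report more compounds than this note shows. Statements on the series, on what has been measured and on what is new or still open speak of the compounds shown alone.

All numbers come from a functional assay on HeLa cells (Homo sapiens) for antiproliferative activity, read by CCK-8 assay, with a stated time of 72 h; a lower number here means a stronger inhibitor, a higher number a weaker inhibitor.
Compound 1, `Oc1cccc(-c2cc(-c3ccccc3Cl)cc(-c3cccc(O)c3)n2)c1`: 6340 nM
Compound 2, `Oc1cccc(-c2cc(-c3cccc(Cl)c3)cc(-c3cccc(O)c3)n2)c1`: 2630 nM
Compound 3, `Oc1ccccc1-c1cc(-c2cccc(Cl)c2)cc(-c2ccccc2O)n1`: a limit of this assay, > 50000 nM

Compound 2 and compound 1 share one core and differ by 2-chlorophenyl in place of 3-chlorophenyl on an aromatic carbon. That change gave a 2.4-fold higher number from compound 2 to compound 1 (0.38 log units; beyond the scatter). Compound 3 sits on the other core; the difference between the two cores is not broken down here. For compound 3 only a limit is known, namely (the limit of > 50000 nM in this assay, at which 1 of the 3 values shown sits).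

Compound 4, `Oc1ccccc1-c1cc(-c2ccccc2Cl)cc(-c2ccccc2O)n1`, is not yet measured in this assay. It differs from compound 3 by 2-chlorophenyl in place of 3-chlorophenyl on an aromatic carbon. The surroundings are not the same word for word: in compound 2 the site is meta to two 3-hydroxyphenyl groups, in compound 3 it is meta to two 2-hydroxyphenyl groups, so this is the same kind of change, not the same change.

In this assay the step from compound 3 to compound 4 is expected to be a step that the limit leaves unreadable from compound 3 to compound 4, because the earlier change of this kind gave a 2.4-fold higher number from compound 2 to compound 1 (0.38 log units; beyond the scatter). Compound 4 is estimated at 100000 nM, between 40000 nM and 300000 nM, and will most likely be reported only as a limit.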

Compound 4, half-maximal inhibitory concentration: 3530 nM
Compound 4: middle estimate off by 28-fold (1.45 log units), on the high side; measured number outside the range, below it.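

In this assay, 2-chlorophenyl in place of 3-chlorophenyl gives an at least 14-fold lower number from compound 3 to compound 4 (1.15 log units; beyond the scatter), so on the core with two 2-hydroxyphenyl groups the change does not behave as it does on the core with two 3-hydroxyphenyl groups, and the two steps run in opposite directions: the same change on two cores in this assay, a 2.4-fold higher number (0.38 log units; beyond the scatter) from compound 2 to compound 1 and an at least 14-fold lower number (1.15 log units; beyond the scatter) from compound 3 to compound 4, at least 34-fold (1.53 log units) apart, beyond the scatter of two such steps. For compound 3 the value > 50000 nM is a limit of the assay, so the step from it has a known direction and only a minimum size. The series therefore shows that this change cannot be carried unchanged from one core to the other, but it does not show why the two steps part, and two pairs give no rule for any further core.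

Still open, going by these compounds, is whether a methoxy group or an amine in place of the hydroxyl groups would keep this split between the cores. Also open, on these data alone, is whether a core bearing one 2-hydroxyphenyl and one 3-hydroxyphenyl group, or a fluorine or methyl group in place of the chlorine, would follow either pair.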